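Series notes: 1,3-thiazol-2-yl to 2-fluoropyridin-4-yl exchange

The compounds below may be only part of what the source reports. "The series", "measured", "known", "first", "only" and "open" are said of these compounds alone.

Of the compounds shown here, two have been measured in an ADME assay on the whole organism (plasma, Rattus norvegicus) for protein binding, using cassette dosing, at a dose of 1 mg/kg (a higher number here means a larger unbound share of the compound, a lower number a smaller unbound share), so far. Compound 1 `CC(C)Oc1ccc(/N=c2\[nH]c(=O)n(C[C@@H](C)C(=O)O)c(=O)n2Cc2ccc(Cl)cc2)cc1Cl` gives 0.002 in this read-out, and compound 2 `C[C@@H](Cn1c(=O)[nH]/c(=N\c2ccc(Oc3nccs3)cc2)n(Cc2ccc(Cl)cc2)c1=O)C(=O)O` gives 0.006 on the same scale. Compound 2 therefore holds the higher of the two numbers, and its gap to compound 1 lies beyond the usual scatter, although both numbers are small.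

Compound 3 `C[C@@H](Cn1c(=O)[nH]/c(=N\c2ccc(Oc3ccnc(F)c3)cc2)n(Cc2ccc(Cl)cc2)c1=O)C(=O)O` is still unmeasured. It carries 2-fluoropyridin-4-yl in place of 1,3-thiazol-2-yl on an oxygen on an aromatic ring and otherwise matches compound 2.

Among the measured compounds shown here, the data contain no step between measured compounds that differ in one place, so this exchange has no direct precedent. Compound 2, at 0.006 in this assay as the sole close reference, anchors the expectation. A small downward move is expected, a 1.2-fold lower number from compound 2 to compound 3 (0.08 log units; within the scatter) as the estimated step, which stays within the scatter. For compound 3 the estimate is 0.005 with an expected range from 0.002 to 0.012 in this measurement.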

Compound 3, unbound fraction: 0.013
Beside the measured number, compound 3's estimate is 2.6-fold (0.41 log units) below it; the whole stated range lies below it.
By their numbers in this assay, from the lowest: compound 1; then compound 2; then compound 3.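

On an oxygen on an aromatic ring, 2-fluoropyridin-4-yl in place of 1,3-thiazol-2-yl gives the series its first step between compounds that differ in one place: in this assay the exchange gives a 2.2-fold higher number from compound 2 to compound 3 (0.34 log units; beyond the scatter). This shows that the group on this oxygen can shift the unbound share by more than the usual scatter while the rest of the molecule stays the same, although the step is modest and compound 3 at 0.013 still has a small unbound fraction. No measurement shown here bears on what lies behind this step.

The compounds shown leave open whether the fluorine or the six-membered pyridine ring accounts for the change, which a plain pyridin-4-yl on the same oxygen would separate. From the compounds shown here alone, they also rest on one exchange against one background, so it remains open whether the step would carry over to other groups, such as a pyrimidin-2-yl or a methyl, or to a compound with the aromatic ring of compound 1.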